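This account rests on a few compounds, and the source may have more. Where it says the series, first, only, none or still open, it means among the compounds named here.

In a functional assay on MCF7 cells (Homo sapiens) for antiproliferative activity, read by MTT assay, with a stated time of 72 h (a lower number here means a stronger inhibitor, a higher number a weaker inhibitor), compound 1, whose structure is `COc1ncc(-c2ccc3c(c2)N(c2ccc(C)cc2)C(=O)CO3)cc1NS(=O)(=O)c1ccc(F)cc1`, gives 15400 nM. Among the two plain numbers shown, compound 1 stands at the lower end, so it is the stronger of that pair. Its nearest neighbour is compound 2, `Cc1ccc(N2C(=O)COc3ccc(-c4cnc(Cl)c(NS(=O)(=O)c5ccc(F)cc5)c4)cc32)cc1`, which in this assay gives 32600 nM; the change of chloro in place of methoxy on an aromatic carbon brought a 2.1-fold higher number from compound 1 to compound 2 (0.33 log units; beyond the scatter). Compound 3, `O=C1COc2ccc(-c3cnc4ccccc4c3)cc2N1c1ccccc1`, reaches only a limit in this assay, > 40000 nM, so no number is known for it; this is the limit of > 40000 nM in this assay, at which 1 of the 3 values shown sits.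

Compound 4, `COc1ncc(-c2ccc3c(c2)N(C(C)C)C(=O)CO3)cc1NS(=O)(=O)c1ccc(F)cc1`, has not yet been measured. It differs from compound 1 by isopropyl in place of 4-methylphenyl on an amide-type nitrogen in a ring. For the measured compounds named here, none of the measured steps touches this position: the only measured step changes a group on an aromatic carbon elsewhere, and compound 3 differs from compound 1 in more than one place, so its limit cannot be read as the effect of the nitrogen substituent alone. Going by the values given here, with no step bearing on the change, the expectation for compound 4 is a step of a 1.3-fold higher number from compound 1 to compound 4 (0.11 log units; within the scatter), that is, within the scatter, but with a wide uncertainty. Compound 4 is therefore estimated at 20000 nM in this assay, within a range from 6000 nM to 60000 nM.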

Compound 4, half-maximal inhibitory concentration: 17000 nM
Beside the measured number, compound 4's estimate is 1.2-fold (0.07 log units) above it; measured number inside the range.
By their numbers in this assay, from the lowest: compounds 1, 4 and 2 (each within the scatter of the next, the first and the last beyond it). At a limit, above all of these: compound 3.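

For the compounds shown here, compound 4 shows for the first time what happens at the amide-type nitrogen in the ring: in this assay, isopropyl in place of 4-methylphenyl gives a 1.1-fold higher number from compound 1 to compound 4 (0.04 log units; within the scatter). Going by these compounds alone, the earlier measured step changed a group on an aromatic carbon elsewhere, so this is the first direct reading at this position, and in this one pair the six-membered aromatic ring of the 4-methylphenyl group is not needed to keep the number where it stands: isopropyl, with no ring and 3 heavy atoms against 7, gives a value that cannot be told apart from that of compound 1. No measurement shown explains why the two substituents match in this way.

The compounds shown leave open whether this position accepts groups of a different kind, such as an amine, a carboxylic acid or a longer chain, just as readily as it accepts isopropyl. They also leave open whether isopropyl on this nitrogen would give the same picture with chloro in place of methoxy on the aromatic carbon, as in compound 2.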